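A few compounds are considered here, and "the series" means these few. Any claim that something is new, unique, unknown or untested is made for them only; others in the source may bear on it.

Measured compounds:
- compound 1 `COc1ccc2c(c1)/C(=C/c1c(-c3ccncc3)nc3sccn13)C(=O)N2C` — 390 nM
- compound 2 `COc1nc2sc(C)cn2c1/C=C1/C(=O)Nc2ccccc21` — 2090 nM

Of the compounds shown here, two have been measured in a functional assay on cells (Prostatic carcinoma cell, Homo sapiens) for cytotoxicity, read by sulforhodamine B assay, with a stated time of 48 h; on this read-out lower numbers stand for stronger inhibition of growth and higher numbers for weaker inhibition of growth. Compound 2 stands at the higher of the two numbers; its nearest neighbour, compound 1, gives a clearly lower number, and the gap between the two is beyond the usual scatter. Among the measured compounds shown here, the two differ in several places at once, so their values show only that compound 1 inhibits growth more strongly than compound 2 in this assay.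

Compound 3 `COc1ccc2c(c1)/C(=C\c1c(OC)nc3sc(C)cn13)C(=O)N2` is not yet measured. Relative to compound 2 it carries methoxy in place of hydrogen on an aromatic carbon. No measured pair shows the effect of this change on its own, so its size cannot be read from the shown numbers. The step from compound 2 to compound 3 is expected to be small, of the size a 1.4-fold lower number from compound 2 to compound 3 (0.14 log units; within the scatter), toward stronger inhibition of growth but possibly within the scatter. Compound 3 is estimated at 1500 nM, in the range 500 nM to 4000 nM.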

Compound 3, concentration for 50% growth inhibition: 380 nM
The estimate for compound 3 lay 3.9-fold (0.60 log units) above the measured number; the whole stated range lies above it.
By their numbers in this assay, from the lowest: compounds 3 and 1 (each within the scatter of the next); then compound 2.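

In this assay, methoxy in place of hydrogen on an aromatic carbon, meta to a fused ring and para to a fused ring, gives a 5.5-fold lower number from compound 2 to compound 3 (0.74 log units; beyond the scatter), toward stronger inhibition of growth. This is the first single change shown, and it establishes that this position of the six-membered aromatic ring of carbon only is sensitive to substitution, which the earlier pair, differing in several places at once, could not reveal. Nothing shown accounts for the size of this step.

As far as these compounds go, whether the gain is specific to methoxy remains open, since a hydroxyl, a chlorine, an amine or the longer ethoxy at the same place could give a smaller, similar or larger step. From the compounds shown here alone, it is also open whether the same change would act alike on the core of compound 1.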